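Series notes: aryl swap on the fused core of compound 1

The source may hold more compounds than are shown below. What is called first, only, known or untested is meant among the compounds shown, and "the series" means these compounds.

Two compounds of the series carry numbers in an assay on isolated protein for agonist activity at Free fatty acid receptor 1 (Homo sapiens); on this read-out lower numbers stand for an effect already at smaller amounts and higher numbers for an effect only at larger amounts of compound. Compound 1 `CC#CC(CC(=O)O)c1ccc(OCc2ccn3cc(-c4cccc(C)c4)nc3c2)cc1` gives 1510 nM in this assay. For the measured compounds named here, compound 2 `CC#CC(CC(=O)O)c1ccc(OCc2ccc3nc(-c4ccc(C(F)(F)F)cc4)cn3c2)cc1` gives 558 nM in this assay, a lower number than compound 1; the two differ in more than one place, so no single step connects them, and only the two numbers themselves can be compared. Compound 1 therefore stands at the highest number of the two measured.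

The next compound, compound 3 `CC#CC(CC(=O)O)c1ccc(OCc2ccn3cc(-c4ccccc4F)nc3c2)cc1`, is reached from compound 1 by one change: 2-fluorophenyl in place of 3-methylphenyl on an aromatic carbon. The 3-methylphenyl leaves, a 2-fluorophenyl enters, and the point of attachment on the five-membered aromatic ring with 2 nitrogen stays the same. Both groups count seven heavy atoms, with neither donors nor acceptors.

Going by the values given here, no measured step isolates such a swap. The expectation for the step from compound 1 to compound 3 in this assay is therefore small, a 1.3-fold lower number from compound 1 to compound 3 (0.10 log units; within the scatter), and not clearly beyond the scatter in either direction. On that basis compound 3 is estimated at 1200 nM in this assay, within a range from 400 nM to 3600 nM.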

Compound 3, half-maximal effective concentration: 705 nM
For compound 3 the middle estimate is 1.7-fold (0.23 log units) above the measured one; low and high end bracket the measured number.
By their numbers in this assay, from the lowest: compounds 2 and 3 (each within the scatter of the next); then compound 1.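

In this assay, the aryl group on the five-membered aromatic ring with 2 nitrogen now has a measured step of its own: a 2.1-fold lower number from compound 1 to compound 3 (0.33 log units; beyond the scatter) for 2-fluorophenyl in place of 3-methylphenyl. For the compounds shown here, compound 1 and compound 2 differ in more than one place, so this is the first sign that the number responds to this aryl group alone, with the rest of compound 1 held constant and the count of seven heavy atoms the same on both sides. No measurement at hand gives a reason for the step.

Still open, going by these compounds, is whether the step belongs to the loss of the methyl group, the gain of the fluorine or the different place of each on the phenyl ring, and an unsubstituted phenyl here would be the reference that separates these readings. Also open, on these data alone, is how the number responds at this position to other groups, such as a pyridyl ring, a cyclohexyl group or a morpholine.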